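Ester to acid on two cores at the orexin-2 receptor

The source may hold more compounds than are shown below. What is called first, only, known or untested is meant among the compounds shown, and "the series" means these compounds.

Compound 1 `COC(=O)c1ccc2ccc(C(=O)c3ccc(C(F)(F)F)cc3)c-2cc1` and compound 2 `O=C(O)c1ccc2ccc(C(=O)c3ccc(C(F)(F)F)cc3)c-2cc1` share one core, while compound 3 `CCOc1ccc(-c2cc(C(=O)c3ccccc3)c3ccc(C(=O)OC)ccc2-3)cc1` is built on another; the difference between the two cores is not broken down here. In an assay on cells for displacement of a labelled ligand from Orexin receptor type 2 (Homo sapiens), read by scintillation counting, with stated times of 10 min and 90 min, tested at 10 uM (a lower number here means less inhibition, a higher number more inhibition at the concentration tested (going by the name of the read-out)), compound 1 gives -47.4%, and compound 2 gives 1%. The change between them, (hydrogen in place of methyl on an oxygen next to a carbonyl group), produced a number 48.4 percentage points higher from compound 1 to compound 2 (beyond the scatter). Compound 3 stands highest of the three measured compounds in this assay with 19.1%. Compound 4 `CCOc1ccc(-c2cc(C(=O)c3ccccc3)c3ccc(C(=O)O)ccc2-3)cc1` carries the same change on the core of compound 3: hydrogen in place of methyl on an oxygen next to a carbonyl group, at a place described in the same words as for compound 1 and compound 2. For the measured compounds named here, because the step of a number 48.4 percentage points higher from compound 1 to compound 2 (beyond the scatter) was large, the same change is expected to raise the number for compound 4 as well, though only one such pair is measured and the starting point of compound 3 differs from that of compound 1, so a smaller step seems more prudent. The step from compound 3 to compound 4 is estimated at a number 25.9 percentage points higher from compound 3 to compound 4 (beyond the scatter), set beside the earlier one. Compound 4 is expected to give about 45% in this assay, likely between 10% and 75%.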

Compound 4, a percentage reported as inhibition, at one concentration (the size of the read-out at that concentration, not a potency): -16.9%
The estimate for compound 4 lay 61.9 percentage points above the measured number, outside the stated range (below it).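

In this assay, the same exchange of methyl for hydrogen on an oxygen next to a carbonyl group gave a number 36 percentage points lower from compound 3 to compound 4 (beyond the scatter), and the two steps run in opposite directions: the same change on two cores in this assay, a number 48.4 percentage points higher (beyond the scatter) from compound 1 to compound 2 and a number 36 percentage points lower (beyond the scatter) from compound 3 to compound 4, 84.4 percentage points apart, beyond the scatter of two such steps For these two cores, then, the direction of the methoxycarbonyl to carboxy change on one core did not predict its direction on the other, so the step seen on the first core cannot simply be transferred to the second. This does not show which difference between the cores reverses the step or why it does so, and with a single pair on each core it gives no general rule for either core.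

The compounds shown leave open whether the reversal depends on the ethoxy group of compound 3 and compound 4, the trifluoromethyl group of compound 1 and compound 2, or the rest of each core. They also leave open how a primary amide in place of the carboxy group would behave on each core.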